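The compounds below may be only part of what the source reports. "The series", "measured", "known", "first", "only" and "open" are said of these compounds alone.

Measured in a functional assay on A-431 cells (Homo sapiens) for cytotoxicity, read by MTT assay, with a stated time of 72 h, tested at 10 uM; a lower number here means less inhibition of growth, a higher number more inhibition of growth at the concentration tested:
compound 1 `N/C(=N\NC(=S)N1CCOCC1)c1ccccn1`: 69.4%
compound 2 `Cc1ccnc(/C(N)=N/NC(=S)N2CCOCC2)c1`: 62%
compound 3 `N/C(=N\NC(=S)N1CCCC1)c1ccc(F)cn1`: 78.7%

Compound 2 sits at the low end of these numbers; against compound 1 the gap is within the scatter, against compound 3 it is beyond it. Among the compounds with values here, the one measured step, a number 7.4 percentage points lower from compound 1 to compound 2 (within the scatter), is within the scatter. Compound 4 `Cc1ccnc(/C(N)=N/NC(=S)N2CCSCC2)c1` is not yet measured; it differs from compound 2 by thiomorpholin-4-yl in place of morpholin-4-yl on a thiocarbonyl carbon. Within the data shown here, no measured step touches the group on the thiocarbonyl carbon: the step from compound 1 to compound 2 concerns a substituent on an aromatic carbon, and compound 3 differs from compound 2 in more than one place, so only its value stands beside that of compound 2. Among the measured compounds shown here, with no step bearing on this change, no step beyond the scatter is expected in this assay; the expected step is no change at the digits printed from compound 2 to compound 4 (within the scatter). For compound 4 the estimate is 62%, with a range of 48% to 76%.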

Compound 4, percent growth inhibition at one concentration: 60%
Compound 4: the middle estimate sits 2 percentage points above what was measured; the measured number falls inside the stated range.
By their numbers in this assay, from the lowest: compounds 4, 2, 1 and 3 (each within the scatter of the next, the first and the last beyond it).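

In this assay, thiomorpholin-4-yl in place of morpholin-4-yl on a thiocarbonyl carbon gives a number 2 percentage points lower from compound 2 to compound 4 (within the scatter), the first step read at this position. In this one pair, the exchange of these two rings leaves the read-out within the scatter, so this position tolerates it at the concentration tested. Nothing on hand gives a reason for this result.

Still open, from the compounds shown here alone, is whether a dimethylamino group or a piperazin-1-yl group on the thiocarbonyl carbon would hold the number. Also open, going by these compounds, is whether the same exchange reads alike on the core of compound 1.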